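The compounds below may be only part of what the source reports. "The series", "measured", "known", "first", "only" and "open" are said of these compounds alone.

Measured compounds in an assay for inhibition of zeta-carotene desaturase, chloroplastic/chromoplastic (Capsicum annuum), using a Dixon plot, with a stated time of 8 h; a lower number here means a stronger inhibitor, a higher number a weaker inhibitor:
Compound 1 `CCC(COc1cccc(C(F)(F)F)c1)OC(=O)NCc1ccccc1`: > 100000 nM, a limit of the assay.
Compound 2 `CCC(COc1cccc(C(C)C)c1)OC(=O)NCc1ccccc1`: > 100000 nM, a limit of the assay.
Compound 3 `CCC(COc1cccc(NC(C)=O)c1)OC(=O)NCc1ccccc1`: > 100000 nM, a limit of the assay.

Compound 1 stands only as a limit in this assay, and the same holds for the other two measured compounds; all three values sit at the limit of > 100000 nM in this assay, at which 3 of the 3 values shown sit. The three exchanges of the group on the aromatic carbon are therefore unreadable: a step that the two limits leave unreadable from compound 1 to compound 2, a step that the two limits leave unreadable from compound 1 to compound 3 and a step that the two limits leave unreadable from compound 2 to compound 3. None of them shows whether the shared core gives any measurable inhibition at all.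

Compound 4 `O=C(NCc1ccccc1)OC(CCl)COc1cccc(C(F)(F)F)c1` is the next step from compound 1: chloro in place of methyl on a saturated chain carbon, two bonds along the chain from an oxygen next to a carbonyl group. Going by the values given here, no measured step touches the saturated chain; the three measured steps all change the group on the aromatic carbon, and each is unreadable. They bear on compound 4 only in that every compound of the shared core tested so far has returned a limit in this assay. Nothing in the numbers argues for a readable gain from a change on the chain, so the expected outcome for compound 4 is another limit, with the step that the limit leaves unreadable from compound 1 to compound 4 expected to be unreadable in the same way. The estimate for compound 4 is 150000 nM, with a range from 50000 nM to 500000 nM.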

Compound 4, half-maximal inhibitory concentration: > 100000 nM
Compound 4 ended at the assay's limit; the forecaster's own chance of this, stated with the estimate: 85%; the middle value lies beyond the limit too.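

No new step can be read between compound 1 and compound 4, since both stand only as limits in this assay. All values shown coincide: the limit of > 100000 nM in this assay, at which 4 of the 4 values shown sit.

The compounds shown leave open whether the shared core gives any measurable inhibition at all, and whether a change on the aromatic carbon or the saturated chain alters it.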